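From 3,4-dichlorophenyl to 2,6-dibromophenyl on a shared core

The compounds below may be only part of what the source reports. "The series", "measured", "known", "first", "only" and "open" are said of these compounds alone.

- Compound 1 (`Cc1oc(-c2ccc(Cl)cc2)nc1CN1CCC(C(=O)NCCCN2C[C@H](C)C[C@H](C)C2)CC1`) in a physicochemical assay for permeability, using PAMPA (a lower number here means that the compound crosses the layer more slowly, a higher number that the compound crosses the layer faster), gives > 635 10^-6 cm/s as a limit, not a number
- Compound 2 (`Cc1oc(-c2ccc(F)cc2)nc1CN1CCC(C(=O)NCCCN2C[C@H](C)C[C@H](C)C2)CC1`) has no reported result in this assay, where compound 2 stands as "not determined" (no result reported)
- Compound 3 (`Cc1oc(-c2ccc(Cl)c(Cl)c2)nc1CN1CCC(C(=O)NCCCN2C[C@H](C)C[C@H](C)C2)CC1`) in this assay gives 522 10^-6 cm/s as a measured number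

Among the compounds with values here, compound 3 holds the only actual number in this assay in this small set, so it has no measured number to be ranked against. Compound 4 (`Cc1oc(-c2c(Br)cccc2Br)nc1CN1CCC(C(=O)NCCCN2C[C@H](C)C[C@H](C)C2)CC1`) carries 2,6-dibromophenyl in place of 3,4-dichlorophenyl on an aromatic carbon of a five-membered aromatic ring with 1 nitrogen and 1 oxygen (2,6-dibromophenyl in place of 3,4-dichlorophenyl on an aromatic carbon). Within the data shown here, one measured step bears on this change, the chloro in place of hydrogen on an aromatic carbon, which gives an at least 1.2-fold lower number from compound 1 to compound 3 (0.08 log units; that floor lies within the scatter) and starts from a limit. Among the measured compounds shown here, no measured compound carries bromine, so that step is only a weak guide, and no change beyond the scatter is expected in this assay on the strength of it. The expected size of the change is a 1.1-fold lower number from compound 3 to compound 4 (0.05 log units; within the scatter) in this estimate. For compound 4 the estimated value is 460 10^-6 cm/s in this assay, with an expected range from 220 10^-6 cm/s to 635 10^-6 cm/s for this measurement.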

Compound 4, apparent permeability: < 1 10^-6 cm/s
Compound 4: no number, only a limit; the forecaster's own chance of this, stated with the estimate: 25%; at least 460-fold (2.66 log units) between middle value and limit.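

In this assay, 2,6-dibromophenyl in place of 3,4-dichlorophenyl gives an at least 520-fold lower number from compound 3 to compound 4 (2.71 log units; beyond the scatter), and 2,6-dibromophenyl in place of 4-chlorophenyl gives an at least 630-fold lower number from compound 1 to compound 4 (2.80 log units; beyond the scatter). Within the data shown here, the earlier step gave only an at least 1.2-fold lower number from compound 1 to compound 3 (0.08 log units; that floor lies within the scatter), so these new steps are the first to show that the read-out depends strongly on which aryl group sits on this aromatic carbon of the five-membered ring. The value of compound 4 is a limit and not a number, so both new steps are floors: the limit of < 1 10^-6 cm/s in this assay, at which 1 of the 4 values shown sits.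

The compounds shown do not separate the change from chlorine to bromine from the change in where the halogens sit on the phenyl ring. A dichlorophenyl group with its chlorines where 2,6-dibromophenyl has its bromines would bear on that question.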